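Nitrofuranyl isoxazoline biaryls: cytotoxicity notes

The source may report more compounds than this note shows. Statements on the series, on what has been measured and on what is new or still open speak of the compounds shown alone.

Measured compounds:
compound 1 `COc1ccc(CN2CCN(c3ccc(C4CC(c5ccc([N+](=O)[O-])o5)=NO4)cc3)CC2)cn1` — in an ADME assay on WI-38 cells (Homo sapiens) for cytotoxicity, read by MTT assay, with a stated time of 96 h (a lower number here means a stronger inhibitor, a higher number a weaker inhibitor), compound 1 gives > 50000 nM, a limit of the assay.
compound 2 `O=[N+]([O-])c1ccc(C2=NOC(c3ccc(-c4cccnc4)cc3)C2)o1` — in this assay compound 2 gives > 50000 nM, a limit of the assay.
compound 3 `O=[N+]([O-])c1ccc(C2=NOC(c3ccc(-c4ccncc4)cc3)C2)o1` — in this assay compound 3 gives > 50000 nM, a limit of the assay.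

Compound 3 thus stands only at a limit, as do all values shown (the limit of > 50000 nM in this assay, at which 3 of the 3 values shown sit). Compound 4 `O=[N+]([O-])c1ccc(C2=NOC(c3ccc(-c4ccccn4)cc3)C2)o1` differs from compound 3 by pyridin-2-yl in place of pyridin-4-yl on an aromatic carbon. For the measured compounds named here, the one step that bears on this change, a step that the two limits leave unreadable from compound 2 to compound 3, lies between two limits and its size cannot be read. Going by the values given here, no measured step therefore supports any shift beyond the scatter in this assay. The step that the limit leaves unreadable from compound 3 to compound 4 is expected to be none beyond the scatter. The estimate for compound 4 in this assay is 80000 nM, ranging from 30000 nM to 300000 nM.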

Compound 4, half-maximal inhibitory concentration: > 50000 nM
Compound 4 was reported as a limit; the forecaster's own chance of this, stated with the estimate: 85%; the middle value lies beyond the limit too.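

For the compounds shown here, compound 4 also sits at a limit, so no step among compound 2, compound 3 and compound 4 can be read: the limit of > 50000 nM in this assay, at which 4 of the 4 values shown sit. Going by these compounds, whether pyridin-2-yl, pyridin-3-yl and pyridin-4-yl differ at all in this assay remains open.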